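Removing the Amino Group from Compound 3

A few compounds are considered here, and "the series" means these few. Any claim that something is new, unique, unknown or untested is made for them only; others in the source may bear on it.

Compound 3 `COc1nc(N)nc2c1c(-c1ccccc1)cn2[C@@H]1O[C@H](CO)[C@@H](O)[C@H]1O` is one of three measured compounds. In a functional assay on CEM-DNR-bulk cells (Homo sapiens), read by MTT assay, with a stated time of 72 h (on this read-out lower numbers stand for stronger inhibition and higher numbers for weaker inhibition), compound 3 gives only a limit, > 20000 nM. Compound 2 `COc1ncnc2c1c(-c1ccoc1)cn2[C@@H]1O[C@H](CO)[C@@H](O)[C@H]1O` likewise reaches only a limit in this assay, > 20000 nM. Both of these limits are the limit of > 20000 nM in this assay, at which 2 of the 3 values shown sit. For the measured compounds named here, compound 1 `COc1ncnc2c1c(-c1ccsc1)cn2[C@@H]1O[C@H](CO)[C@@H](O)[C@H]1O` is the single measured compound with a number in this assay, 7640 nM. Going by the values given here, the only step between measured compounds, an at least 2.6-fold higher number from compound 1 to compound 2 (0.41 log units; beyond the scatter), concerns a different part of the molecule. Compound 4 `COc1ncnc2c1c(-c1ccccc1)cn2[C@@H]1O[C@H](CO)[C@@H](O)[C@H]1O` differs from compound 3 by hydrogen in place of amino on an aromatic carbon. Among the compounds with values here, no measured step covers this change, so its size and direction rest on no direct evidence. Compound 4 is expected to give about 8000 nM, within a range from 2000 nM to 25000 nM. The expected step is an at least 2.5-fold lower number from compound 3 to compound 4 (0.39 log units; beyond the scatter), with wide uncertainty.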

Compound 4, half-maximal inhibitory concentration: > 20000 nM
Compound 4 was reported as a limit (the forecaster's own chance of this, stated with the estimate: 30%); at least 2.5-fold (0.39 log units) between middle value and limit.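

In this assay, compound 4 is a limit just as compound 3 is, so taking away the amino group gives no readable change, and the steps to compound 4 from compound 3 and from compound 2 cannot be read. Phenyl in place of thiophen-3-yl on the shared core can be read, as an at least 2.6-fold higher number from compound 1 to compound 4 (0.41 log units; beyond the scatter). Compound 4 adds one more value to those held at a limit: the limit of > 20000 nM in this assay, at which 3 of the 4 values shown sit.

Going by these compounds, whether hydrogen or amino on this carbon between two ring nitrogen atoms gives the lower number stays open. Also open, on these data alone, is how a methylamino group or a chlorine there would read.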